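Fluoro for Chloro on the Shared Core

This account rests on a few compounds, and the source may have more. Where it says the series, first, only, none or still open, it means among the compounds named here.

Measured compounds:
compound 1, `CN(C)CCn1c(=O)c(=Cc2ccc(F)c(F)c2)s/c1=C1\C(=O)Nc2ccc(F)cc21`, 44700 nM
compound 2, `CN(C)CCn1c(=O)c(=Cc2ccc(O)cc2)s/c1=C1\C(=O)Nc2ccc(Cl)cc21`, 2030 nM

Among the measured compounds shown here, in a functional assay on NCI-H460 cells (Homo sapiens) for inhibition, read by MTT assay, with a stated time of 72 h (a higher number here means a weaker inhibitor, a lower number a stronger inhibitor), compound 2 gives 2030 nM, the lowest of the two numbers so far. Compound 1 gives 44700 nM, a higher number separated from compound 2 by a gap beyond the scatter. Compound 1 and compound 2 differ in more than one place, so their two values show only that gap and isolate no single change.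

Compound 3 `CN(C)CCn1c(=O)c(=Cc2ccc(O)cc2)s/c1=C1\C(=O)Nc2ccc(F)cc21` has not been measured. It differs from compound 2 in one place: fluoro in place of chloro on an aromatic carbon. For the measured compounds named here, no step between measured compounds isolates this exchange, so the expectation rests on compound 2 alone. A modest move towards a higher number, near the edge of the scatter, is expected, as a 2.0-fold higher number from compound 2 to compound 3 (0.29 log units; within the scatter). Compound 3 is therefore estimated at 4000 nM, with a range from 1500 nM to 15000 nM.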

Compound 3, half-maximal inhibitory concentration: 1270 nM
Compound 3: middle estimate off by 3.1-fold (0.50 log units), on the high side, and the stated range ends above it.
By their numbers in this assay, from the lowest: compounds 3 and 2 (each within the scatter of the next); then compound 1.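

On the shared core carrying the 4-hydroxyphenyl group, fluoro in place of chloro on the aromatic carbon gives a 1.6-fold lower number from compound 2 to compound 3 (0.20 log units; within the scatter) in this assay, so this exchange at this position does not move the number beyond the scatter. The change of 4-hydroxyphenyl in place of 3,4-difluorophenyl on the double-bonded chain carbon gives a 35-fold lower number from compound 1 to compound 3 (1.55 log units; beyond the scatter), so among these compounds the large step lies with that aryl exchange and not with the halogen exchange. Nothing measured here accounts for either step.

On these data alone, it remains open whether a methoxy group or an amine in place of the halogen would leave the number within the scatter. As far as these compounds go, it is also open whether the hydroxyl group or the absence of the two fluoro groups carries the large step.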